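Second chloro on the core: compound 3 awaits measurement

A few compounds are considered here, and "the series" means these few. Any claim that something is new, unique, unknown or untested is made for them only; others in the source may bear on it.

Among the measured compounds shown here, compound 2 `ClCc1cccc(Cn2cnc3ncnc(Cl)c32)c1` gives 13200 nM in a functional assay on BT-549 cells (Homo sapiens) for cytotoxicity, read by sulforhodamine B assay, with a stated time of 48 h (a lower number here means a stronger inhibitor of growth, a higher number a weaker inhibitor of growth), the highest of the two numbers so far. Compound 1 `ClCc1ccc(Cn2cnc3c(Cl)ncnc32)cc1` gives 5620 nM in this assay, a lower number, beyond the scatter. Compound 3 `ClCc1cccc(Cn2cnc3nc(Cl)nc(Cl)c32)c1` is not yet measured; it differs from compound 2 by chloro in place of hydrogen on an aromatic carbon, between two ring nitrogen atoms, meta to a chloro group. For the measured compounds named here, no comparable step is measured here, so a small step in this assay, toward a lower number and barely beyond the scatter, is expected. Compound 3 is estimated at 8000 nM (range 2500 nM to 25000 nM). That expectation means a step of a 1.7-fold lower number from compound 2 to compound 3 (0.22 log units; within the scatter).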

Compound 3, concentration for 50% growth inhibition: 480 nM
Compound 3: the middle estimate sits 17-fold (1.22 log units) above what was measured, and the stated range ends above it.
By their numbers in this assay, from the lowest: compound 3; then compound 1; then compound 2.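

In this assay, chloro in place of hydrogen on an aromatic carbon, between two ring nitrogen atoms, gives a large step (a 28-fold lower number from compound 2 to compound 3 (1.44 log units; beyond the scatter)) beyond the scatter. This position is thus sensitive to substitution, a point that compounds 1 and 2 could not show, although the finding rests on a single pair. No measurement at hand explains the size of the step.

As far as these compounds go, whether the step is specific to chloro remains open. An amine, a methoxy group or a methyl group at this position would test that.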